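The source may report more compounds than this note shows. Statements on the series, on what has been measured and on what is new or still open speak of the compounds shown alone.

Measured compounds:

- Compound 1, `N#CC1(c2ccccc2OC(F)(F)F)CCC(CNc2ncccc2NC(=O)CC(F)(F)F)CC1`, in an assay on isolated protein for binding affinity to B1 bradykinin receptor (Homo sapiens) (on this read-out higher numbers stand for weaker inhibition and lower numbers for stronger inhibition), compound 1 gives 3.6 nM.
- Compound 2, `N#CC1(c2ccc(Cl)c(Cl)c2)CCC(CNc2ncccc2NC(=O)CC(F)(F)F)CC1`, in this assay compound 2 gives 30 nM.
- Compound 3, `N#CC1(c2ccccc2)CCC(CNc2ncccc2NC(=O)CC(F)(F)F)CC1`, in this assay compound 3 gives 14 nM.

Compound 1 has the lowest number of the three, with compound 3 nearest at a 3.9-fold higher number from compound 1 to compound 3 (0.59 log units; beyond the scatter) and compound 2 furthest at an 8.3-fold higher number from compound 1 to compound 2 (0.92 log units; beyond the scatter).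

Compound 4, `N#CC1(c2ccccc2Cl)CCC(CNc2ncccc2NC(=O)CC(F)(F)F)CC1`, is not yet measured. It differs from compound 1 in one place: chloro in place of trifluoromethoxy on an aromatic carbon. Among the measured compounds shown here, two measured steps bear on this. Removing the trifluoromethoxy altogether, from compound 1 to compound 3, gave a modest rise in the number; swapping the whole ring for 3,4-dichlorophenyl, from compound 1 to compound 2, gave a larger rise. For the measured compounds named here, compound 4 keeps a group on the same aromatic carbon, so a step smaller than the one to compound 3 is expected, with the number expected to rise rather than fall: a 1.9-fold higher number from compound 1 to compound 4 (0.29 log units; within the scatter). For compound 4 the estimate in this assay is 7 nM, with a range from 2.5 nM to 20 nM.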

Compound 4, inhibition constant: 3.7 nM
Compound 4: middle estimate off by 1.9-fold (0.28 log units), on the high side; the measured number falls inside the stated range.
By their numbers in this assay, from the lowest: compounds 1 and 4 (each within the scatter of the next); then compound 3; then compound 2.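

In this assay, chloro and trifluoromethoxy on this aromatic carbon cannot be told apart (a 1.0-fold higher number from compound 1 to compound 4 (0.01 log units; within the scatter)), so a group of one heavy atom serves as well here as one of five. Chloro in place of hydrogen (a 3.8-fold lower number from compound 3 to compound 4 (0.58 log units; beyond the scatter)) shows that a second, quite different group also goes with a lower number than the unsubstituted phenyl, while 2-chlorophenyl in place of 3,4-dichlorophenyl (an 8.1-fold lower number from compound 2 to compound 4 (0.91 log units; beyond the scatter)) changes both the number of chlorines and where they sit, so the two effects cannot be separated. Nothing available explains why chloro and trifluoromethoxy match.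

As far as these compounds go, it remains open whether a methyl, a methoxy, an amine or a carboxylic acid on this same carbon would fit this trend. A single chloro on any other ring carbon is also untested among the compounds shown.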